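The source may report more compounds than this note shows. Statements on the series, on what has been measured and on what is new or still open speak of the compounds shown alone.

Among the compounds with values here, in a functional assay on the whole organism for antagonist activity, with Mus musculus as the target (on this read-out higher numbers stand for an effect only at larger amounts of compound and lower numbers for an effect already at smaller amounts), only two compounds have been read so far. Compound 1 (`Cn1c(-c2cccs2)nnc1S(C)(=O)=O`) gives > 200 mg/kg, which is a limit of the assay and not a number. Within the data shown here, compound 2 (`Cn1c(-c2ccccc2)nnc1[S+](C)[O-]`) gives 18.6 mg/kg, the only actual number on this read-out. Compound 3 (`CCS(=O)(=O)c1nnc(-c2ccccc2)n1C`) changes compound 2 in one place: a group of 5 heavy atoms (2 carbon, 2 oxygen, 1 sulfur; no ring) in place of a group of 3 heavy atoms (1 carbon, 1 oxygen, 1 sulfur; no ring), on an aromatic carbon. Among the measured compounds shown here, no measured single-place step is available to guide this change. In this assay the estimated step of a 1.9-fold higher number from compound 2 to compound 3 (0.27 log units; within the scatter) is a modest one toward larger doses, near the edge of the scatter. Compound 3 is expected at 35 mg/kg, within an estimated range of 10 mg/kg to 120 mg/kg.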

Compound 3, dose for half-maximal effect: 19.3 mg/kg
Compound 3: the middle estimate sits 1.8-fold (0.26 log units) above what was measured, and the stated range covers the measured number.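

The change gives a 1.0-fold higher number from compound 2 to compound 3 (0.02 log units; within the scatter) in this assay, so on this aromatic carbon the dose does not separate ethylsulfonyl from the smaller sulfur group of compound 2. This pair therefore shows that the position accepts the group of 5 heavy atoms with no change beyond the scatter. No measurement shown offers a reason for this result. Still open, as far as these compounds go, is whether a longer chain on the sulfur would also leave the dose in place, and whether an amine or a carboxylic acid on this carbon would do the same.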